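A few compounds are considered here, and "the series" means these few. Any claim that something is new, unique, unknown or untested is made for them only; others in the source may bear on it.

Measured in a functional assay on HeLa cells (Homo sapiens) for antiproliferative activity, read by MTT assay, with a stated time of 48 h; a higher number here means a weaker inhibitor, a lower number a stronger inhibitor:

Compound 1 `S=c1oc(-c2ccc3c(c2)OCCO3)nn1CN1CCN(C(c2ccccc2)c2ccccc2)CC1`: > 50000 nM, a limit
Compound 2 `Fc1ccccc1N1CCN(Cn2nc(-c3ccc4c(c3)OCCO4)oc2=S)CC1`: 37300 nM
Compound 3 `S=c1oc(-c2ccc3c(c2)OCCO3)nn1CN1CCN(c2cccc(Cl)c2Cl)CC1`: > 50000 nM, a limit

Compound 3 has no numerical reading in this assay, only the limit > 50000 nM. It sits with compound 1 at the limit of > 50000 nM in this assay, at which 2 of the 3 values shown sit, so its true position is not known.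

The next compound, compound 4 `S=c1oc(-c2ccc3c(c2)OCCO3)nn1CN1CCN(c2cccc(Cl)c2)CC1`, is not yet measured. It carries hydrogen in place of chloro on an aromatic carbon, which turns the 2,3-dichlorophenyl of compound 3 into 3-chlorophenyl.

Among the compounds with values here, only one measured step bears on this change: an at least 1.3-fold higher number from compound 2 to compound 3 (0.12 log units; that floor lies within the scatter). It replaces 2-fluorophenyl with 2,3-dichlorophenyl on an amine nitrogen in a ring, so it touches the same group, but it is not the same change. Its one end is a limit, and it gives no size beyond the scatter. No step beyond the scatter is therefore expected in this assay, and no direction can be firmly assigned. Compound 4 is expected to stay in the weak range marked by compound 2 at 37300 nM. It may well reach the limit of the assay.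

The estimated step is an at least 1.2-fold lower number from compound 3 to compound 4 (0.09 log units; that floor lies within the scatter). For compound 4 the estimated value is 40000 nM, with an expected range from 15000 nM to 70000 nM.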

Compound 4, half-maximal inhibitory concentration: 47200 nM
Estimate against measurement, compound 4: 1.2-fold (0.07 log units) below; measured number inside the range.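

In this assay, taking one chloro group off the 2,3-dichlorophenyl of compound 3 to leave the 3-chlorophenyl of compound 4 gives an at least 1.0-fold lower number from compound 3 to compound 4 (0.02 log units; that floor lies within the scatter), so this change shows no shift that can be told from the scatter. Within the data shown here, compound 4 also puts a number on a chlorophenyl group at this position for the first time, and a swap of 2-fluorophenyl for 3-chlorophenyl gives a 1.3-fold higher number from compound 2 to compound 4 (0.10 log units; within the scatter), which leaves the two halogen-bearing aryl groups in compound 2 and compound 4 indistinguishable in this assay and both in the weak range. The reading for compound 3 remains a limit, so the true size of the chloro removal cannot be fixed from this pair: the limit of > 50000 nM in this assay, at which 2 of the 4 values shown sit.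

The compounds shown leave open whether a group on the phenyl ring that carries no halogen, such as a methoxy group or an amine, would move the reading beyond the scatter. They also leave open whether a carboxylic acid or a longer chain on that ring, or a change in the shared core, would do so.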